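The source may hold more compounds than are shown below. What is called first, only, known or untested is meant among the compounds shown, and "the series" means these compounds.

Measured in an assay on isolated protein for inhibition of Amine oxidase [flavin-containing] A (Homo sapiens), read by fluorescence and spectrophotometry, with a stated time of 20 min; on this read-out lower numbers stand for stronger inhibition and higher numbers for weaker inhibition:
compound 1 `O=C1/C(=C/c2cccc(Cl)c2)Cc2cc(O)ccc21`: 157 nM
compound 2 `O=C1/C(=C/c2ccc(Cl)c(Cl)c2)Cc2cc(O)ccc21`: 235 nM

For the measured compounds named here, compound 1 holds the lower of the two numbers, with compound 2 nearest; the one measured step, a 1.5-fold higher number from compound 1 to compound 2 (0.18 log units; within the scatter), is an added chloro on the same ring. Compound 3 `O=C1/C(=C/c2cccc(O)c2)Cc2cc(O)ccc21` differs from compound 1 by hydroxy in place of chloro on an aromatic carbon. Going by the values given here, no measured step swaps one group for another on this ring, so the measured step bears on the change only loosely, though the one change that was measured on this ring left the number within the scatter. The expected step is therefore small, a 1.6-fold higher number from compound 1 to compound 3 (0.20 log units; within the scatter). Compound 3 is estimated at 250 nM, in a range from 80 nM to 800 nM.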

Compound 3, half-maximal inhibitory concentration: 1200 nM
The estimate for compound 3 lay 4.8-fold (0.68 log units) below the measured number, and the stated range ends below it.
By their numbers in this assay, from the lowest: compounds 1 and 2 (each within the scatter of the next); then compound 3.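

In this assay this place on the ring proves sensitive to what sits there: hydroxy in place of chloro gives a 7.6-fold higher number from compound 1 to compound 3 (0.88 log units; beyond the scatter). Compounds 1 and 2 both keep the chloro here, so only compound 3 reveals this sensitivity. Nothing shown accounts for the size of this step. Open, as far as these compounds go, is whether the loss follows from removing chloro or from introducing hydroxy. A methoxy, an amine or a bromo at this same place would show whether other groups stay nearer compound 1 or compound 3.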